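This account rests on a few compounds, and the source may have more. Where it says the series, first, only, none or still open, it means among the compounds named here.

Notes on the series. Compound 1 `COc1cc(SC)nc(NC(=S)NC(=O)c2c(-c3ccc(Cl)cc3Cl)noc2C)n1` has been measured in a functional assay on the whole organism for inhibition, with Digitaria ciliaris as the target, with a stated time of 72 h, tested at 100 mg/L (a higher number here means more inhibition of growth at the concentration tested, a lower number less inhibition of growth), where compound 1 gives 55.6%. Compound 2 `Cc1onc(-c2ccc(Cl)cc2Cl)c1C(=O)/N=c1/nc2nc(Cl)cc(C)n2s1` gives 68.1% in this assay, a number beyond the scatter above compound 1. Compound 3 `Cc1cc(O)nc(NC(=S)NC(=O)c2c(-c3ccc(Cl)cc3Cl)noc2C)n1` gives 49.3% in this assay; the step of a number 6.3 percentage points lower from compound 1 to compound 3 (within the scatter) stays within the scatter, so compound 1 and compound 3 cannot be told apart on these numbers. Compound 4 `COc1cc(OC)nc(NC(=S)NC(=O)c2c(-c3ccc(Cl)cc3Cl)noc2C)n1` is not yet measured. Relative to compound 1 the change is methoxy in place of methylsulfanyl on an aromatic carbon. Within the data shown here, the only measured step that touches the same ring is a number 6.3 percentage points lower from compound 1 to compound 3 (within the scatter), where a broader exchange of groups on that ring produced no step beyond the scatter; compound 2 is of a different build and gives no guidance here. For the exchange of methylsulfanyl for methoxy no step beyond the scatter is expected in this assay, in either direction. The step to compound 4 is therefore estimated as a number 2.6 percentage points lower from compound 1 to compound 4 (within the scatter). Compound 4 is expected to give 53% in this assay, between 38% and 68%.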

Compound 4, percent growth inhibition at one concentration: 65.9%
Compound 4: middle estimate off by 12.9 percentage points, on the low side, and the stated range covers the measured number.
By their numbers in this assay, from the lowest: compounds 3 and 1 (each within the scatter of the next); then compounds 4 and 2 (each within the scatter of the next).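

Working notes: in this assay the exchange of methylsulfanyl for methoxy, on the aromatic carbon next to the ring nitrogen, gives a number 10.3 percentage points higher from compound 1 to compound 4 (beyond the scatter) as a modest step, so this one position registers in the read-out, which the broader ring exchange between compound 1 and compound 3 had not shown. The wider comparison, a number 16.6 percentage points higher from compound 3 to compound 4 (beyond the scatter) and also modest, separates the 4,6-dimethoxypyrimidin-2-yl group from the 4-hydroxy-6-methylpyrimidin-2-yl group, although the step from compound 1 to compound 3 alone stayed within the scatter. No supporting measurement is available to explain why this exchange moves the number. From the compounds shown here alone, whether ethoxy or an amine at this position would go further than methoxy remains open. Also open, going by these compounds, is whether the step survives when the second methoxy group on the ring is exchanged.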